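Replacing 4-chloropiperidin-1-yl with 4-methylpiperazin-1-yl on compound 3

A few compounds are considered here, and "the series" means these few. Any claim that something is new, unique, unknown or untested is made for them only; others in the source may bear on it.

In a functional assay on HepG2 cells (Homo sapiens) for cytotoxicity, read by MTT assay, with a stated time of 48 h (a lower number here means a stronger inhibitor, a higher number a weaker inhibitor), compound 1 (`CC1=NN(C(=O)COc2ccc(Cl)cc2)C(c2ccccc2O)C1`) is reported as "not active" (no number reported) and so offers no number for comparison. Compound 2 (`CC1=NN(C(=O)CN2CCCC2)C(c2ccccc2O)C1`) gives 5540 nM in this assay while compound 3 (`CC1=NN(C(=O)CN2CCC(Cl)CC2)C(c2ccccc2O)C1`) gives 42100 nM as the higher of the two numbers. Compound 4 (`CC1=NN(C(=O)CN2CCN(C)CC2)C(c2ccccc2O)C1`) has not yet been measured. It carries 4-methylpiperazin-1-yl in place of 4-chloropiperidin-1-yl on a saturated chain carbon bound to a carbonyl carbon. Among the measured compounds shown here, the only measured step at this place is a 7.6-fold higher number from compound 2 to compound 3 (0.88 log units; beyond the scatter) and it leaves compound 3 at the high end of the numbers. For the measured compounds named here, no measured compound carries the entering group, so this one step is a thin guide. A smaller step than that one, towards a lower number, is therefore expected in this assay rather than a further rise. The estimated change is a 2.8-fold lower number from compound 3 to compound 4 (0.45 log units; beyond the scatter) and it remains tentative. For compound 4 the estimated value is 15000 nM (expected range 5000 nM to 42000 nM).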

Compound 4, half-maximal inhibitory concentration: "not active" (no number reported)
The entry for compound 4 holds no number; there is nothing to compare the estimate with.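

Compound 4 is reported in this assay as "not active" (no number reported), so no new step can be read from compound 3 to compound 4. Nothing shown bears on this result. The compounds shown leave open how 4-methylpiperazin-1-yl compares numerically with 4-chloropiperidin-1-yl or pyrrolidin-1-yl.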